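This account rests on a few compounds, and the source may have more. Where it says the series, first, only, none or still open, it means among the compounds named here.

Series notes. Compound 2 `CCN1CCc2c(sc(NC(=O)Nc3ccc(Cl)cc3)c2C(N)=O)C1` gives 3120 nM in a functional assay (strain AB) with Danio rerio as the target, read by microscopy, with a stated time of 1 h; a lower number here means that less compound is needed, a higher number that more compound is needed for the effect. Compound 1 `CC(C)CN1CCc2c(sc(NC(=O)Nc3ccc(Cl)cc3)c2C(N)=O)C1` gives 4510 nM in this assay, and compound 3 `NC(=O)c1c(NC(=O)Nc2ccc(Cl)cc2)sc2c1CCN(CC1CCC1)C2` gives 1360 nM. Compound 2 thus stands second highest of the three numbers, with a 1.4-fold lower number from compound 1 to compound 2 (0.16 log units; within the scatter) and a 2.3-fold lower number from compound 2 to compound 3 (0.36 log units; beyond the scatter), and the remaining step is a 3.3-fold lower number from compound 1 to compound 3 (0.52 log units; beyond the scatter). All three measured steps alter only the group on the saturated chain carbon bound to the amine nitrogen in the ring.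

Compound 4 `CCN1CCc2c(sc(NC(=O)Nc3ccc(Cl)cc3)c2C(=O)O)C1` differs from compound 2 at another place: hydroxy in place of amino on a carbonyl carbon, or carbamoyl to carboxy when the cut is taken one bond further out. Among the measured compounds shown here, no measured step involves that carbonyl carbon, so none of the steps among compound 1, compound 2 and compound 3 bears on this change, and their sizes give no guide to its direction. The expectation for compound 4 rests on compound 2 alone and is a step of a 1.9-fold higher number from compound 2 to compound 4 (0.28 log units; within the scatter) in this assay, held loosely. Compound 4 is estimated at 6000 nM, expected to fall between 1500 nM and 30000 nM.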

Compound 4, half-maximal effective concentration: > 25000 nM
Compound 4: only a limit was reported (the forecaster's own chance of this, stated with the estimate: 25%); middle value at least 4.1-fold (0.61 log units) from the limit.
By their numbers in this assay, from the lowest: compound 3; then compounds 2 and 1 (each within the scatter of the next). At a limit, above all of these: compound 4.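

Hydroxy in place of amino on a carbonyl carbon gives an at least 8.0-fold higher number from compound 2 to compound 4 (0.90 log units; beyond the scatter) in this assay, so this position, untouched by the earlier steps, responds more strongly than the group on the saturated chain carbon, where the largest step is a 3.3-fold lower number from compound 1 to compound 3 (0.52 log units; beyond the scatter). Among the compounds shown here, on the core of compound 2, carbamoyl needs far less compound for the effect than carboxy, although only this one pair shows it. Compound 4 stands at a limit of the assay, not at a number: the limit of > 25000 nM in this assay, at which 1 of the 4 values shown sits.

As far as these compounds go, how far compound 4 lies past that limit stays open, and with it the true size of the step. Also open, from the compounds shown here alone, are whether a methyl ester or a methylamide in place of carbamoyl would keep the number of compound 2, and whether carboxy would have a similar effect on the core of compound 1 or compound 3.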